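Urea series: fluoro in place of methyl on the core

The source may report more compounds than this note shows. Statements on the series, on what has been measured and on what is new or still open speak of the compounds shown alone.

Measured so far:
compound 1 `Cc1cccc2c1CCN2CCNC(=O)Nc1ccccc1Br` — 7.4
compound 2 `O=C(Nc1ccccc1Br)N[C@@H]1CCN(c2cccc(C(F)(F)F)n2)C1` — 7.2

Both compounds were run in a functional assay for antagonist activity at transient receptor potential cation channel subfamily V member 1 (Rattus norvegicus), read by FLIPR; a higher number here means a more potent compound, by a factor of ten per unit of this negative logarithm, a lower number a less potent compound. Compound 1 gives 7.4 and stands highest of the two numbers; compound 2 gives 7.2, which lies within the scatter of compound 1, so no order between them is claimed.

Compound 3 `O=C(NCCN1CCc2c(F)cccc21)Nc1ccccc1Br` is not yet measured. It differs from compound 1 only by fluoro in place of methyl on an aromatic carbon. The exchange swaps one heavy atom for one heavy atom on an aromatic carbon of the fused system, leaving the urea and the bromophenyl end untouched.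

Going by the values given here, no step between measured compounds maps this change, so the expectation rests on the size of the change alone. For compound 3 the step from compound 1 is expected to be small, a number 0.20 log units lower from compound 1 to compound 3 (within the scatter), most likely none beyond the scatter. Compound 3 is estimated at 7.2, with a range of 6.6 to 7.8 in this assay.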

Compound 3, negative logarithm of the antagonist equilibrium constant: 7.4
Compound 3: middle estimate off by 0.20 log units, on the low side; the range from low to high includes it.
By their numbers in this assay, from the lowest: compounds 2, 1 and 3 (each within the scatter of the next).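

Fluoro in place of methyl on an aromatic carbon of the shared core gives, in this assay, no change at the digits printed from compound 1 to compound 3 (within the scatter). Going by these compounds alone, this is the first measured step at this position, and it shows that the methyl of compound 1 is not needed to hold the number in this assay, since a single fluorine serves equally well on this carbon. Nothing measured here bears on why the two groups read alike.

The compounds shown leave open how far this position stays flat, since this one exchange does not cover an unsubstituted carbon or a methoxy, an amine or a carboxylic acid on the same carbon. They also leave open whether fluoro in place of methyl would read the same on the other aromatic carbons of the core.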